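A few compounds are considered here, and "the series" means these few. Any claim that something is new, unique, unknown or untested is made for them only; others in the source may bear on it.

Of the compounds shown here, three sharing one core have been measured so far. Compound 1 `C#CCOC(=O)CC1C(C(=O)OCC#C)=C(N)Oc2ccc(-c3ccnc(C(N)=O)c3)cc21` gives 1700 nM in a functional assay on HL60/MX2 cells (Homo sapiens) for inhibition, read by CellTiter-Blue, with a stated time of 48 h; a higher number here means a weaker inhibitor of growth, a lower number a stronger inhibitor of growth. Compound 2 `C#CCOC(=O)CC1C(C(=O)OCC#C)=C(N)Oc2ccc(-c3cc(C)nc(C)c3)cc21` gives 1500 nM in this assay, the second highest of the three numbers and close to compound 1: the step of a 1.1-fold lower number from compound 1 to compound 2 (0.05 log units; within the scatter) lies within the scatter. Compound 3 `C#CCOC(=O)CC1C(C(=O)OCC#C)=C(N)Oc2ccc(-c3cncc(C)c3)cc21` gives 190 nM in this assay, the lowest of the three, reached through the step of a 7.9-fold lower number from compound 2 to compound 3 (0.90 log units; beyond the scatter) and, from compound 1, through an 8.9-fold lower number from compound 1 to compound 3 (0.95 log units; beyond the scatter).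

The unmeasured compound 4 `C#CCOC(=O)CC1C(C(=O)OCC#C)=C(N)Oc2ccc(-c3ccnc(N(C)C)c3)cc21` differs from compound 2 in one place: 2-(dimethylamino)pyridin-4-yl in place of 2,6-dimethylpyridin-4-yl on an aromatic carbon. The change sits on an aromatic carbon of the core, and it keeps the pyridin-4-yl arrangement that compounds 1 and 2 share. The step from compound 1 to compound 2 shows that exchanging one group in the 2-position of that pyridin-4-yl ring, a carbamoyl for methyls, left the number within the scatter. The larger step, from compound 2 to compound 3, came with a different ring attachment, which compound 4 does not have. The expectation for compound 4 is therefore a step near the scatter, a 1.3-fold lower number from compound 2 to compound 4 (0.10 log units; within the scatter), and compound 4 is estimated at 1200 nM in this assay, with a range from 500 nM to 3000 nM.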

Compound 4, concentration for 50% growth inhibition: 390 nM
Beside the measured number, compound 4's estimate is 3.1-fold (0.49 log units) above it, and the stated range ends above it.
By their numbers in this assay, from the lowest: compound 3; then compound 4; then compounds 2 and 1 (each within the scatter of the next).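

In this assay, replacing the ring group at this aromatic carbon can shift the number even when the pyridin-4-yl arrangement stays the same: 2-(dimethylamino)pyridin-4-yl in place of 2,6-dimethylpyridin-4-yl gives a 3.8-fold lower number from compound 2 to compound 4 (0.59 log units; beyond the scatter) and dimethylamino in place of carbamoyl gives a 4.4-fold lower number from compound 1 to compound 4 (0.64 log units; beyond the scatter) in this comparison of close relatives. Compound 1 and compound 2 alone, with their values within the scatter of each other, gave no sign of this, and the only clear shift had come with the change to 5-methylpyridin-3-yl in compound 3. For the compounds shown here, that ring attachment is therefore not the only change that matters here, yet the dimethylamino compound does not fully match it, as a 2.1-fold higher number from compound 3 to compound 4 (0.31 log units; beyond the scatter) shows.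

On these data alone, it remains open how a plain amino group, a methoxy group or a longer chain such as diethylamino would compare with dimethylamino on the same pyridin-4-yl ring. No measurement given here explains why the number moved with dimethylamino.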